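Trimming the Piperazine Substituent: From Isopropyl to Methyl

The compounds below may be only part of what the source reports. "The series", "measured", "known", "first", "only" and "open" are said of these compounds alone.

- compound 1 `c1ccc2c(c1)CN[C@@H](CN(CC[C@@H]1CCCNC1)[C@H]1CCCc3cccnc31)C2`: 75%
- compound 2 `CC(C)N1CCN(CCCN(C[C@H]2Cc3ccccc3CN2)[C@H]2CCCc3cccnc32)CC1`: 46%
- compound 3 `c1cnc2c(c1)CN[C@@H](CN(CCCN1CCNCC1)[C@H]1CCCc3cccnc31)C2`: 79%

In an ADME assay on microsomes from liver (Homo sapiens) for metabolic stability, read by LC-MS, with a stated time of 10 min, tested at 0.5 uM (on this read-out lower numbers stand for a less stable compound and higher numbers for a more stable compound), compound 2 stands lowest of the three, with compound 1 and compound 3 both higher by more than the scatter. Compound 4 `CN1CCN(CCCN(C[C@H]2Cc3ccccc3CN2)[C@H]2CCCc3cccnc32)CC1` differs from compound 2 in one place: methyl in place of isopropyl on an amine nitrogen in a ring. It carries methyl in place of isopropyl on an amine nitrogen in a ring.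

Going by the values given here, no measured step isolates this change. The nearest is a number 29 percentage points lower from compound 1 to compound 2 (beyond the scatter), where (4-isopropylpiperazin-1-yl)methyl replaced piperidin-3-yl, a much larger exchange. Compound 3, at 79%, lacks the isopropyl but also differs in the core, so its value gives only a loose hint of direction. A smaller upward move than that measured step therefore seems likely, though the data leave room for little change. The expected move is a number 12 percentage points higher from compound 2 to compound 4 (beyond the scatter). Compound 4 is estimated at 58%, with an expected range of 42% to 74%.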

Compound 4, percent of the compound remaining: 72%
Compound 4: the middle estimate sits 14 percentage points below what was measured, and the stated range covers the measured number.
By their numbers in this assay, from the lowest: compound 2; then compounds 4, 1 and 3 (each within the scatter of the next).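

In this assay, putting methyl in place of isopropyl on the amine nitrogen of the ring gives a number 26 percentage points higher from compound 2 to compound 4 (beyond the scatter), the first step shown that isolates this one position. With methyl in that place, the larger exchange of the side chain gives a number 3 percentage points lower from compound 1 to compound 4 (within the scatter), so the earlier drop of a number 29 percentage points lower from compound 1 to compound 2 (beyond the scatter) does not carry over to the 4-methylpiperazin-1-yl compound and is tied in this set to the isopropyl. Nothing available explains why the two groups read so differently.

On the shared core, the compounds shown carry only isopropyl and methyl on this nitrogen, so it stays open whether the read-out tracks the size of the group or is particular to isopropyl. An ethyl or an acetyl on the same nitrogen would test this.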